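The source may hold more compounds than are shown below. What is called first, only, known or untested is meant among the compounds shown, and "the series" means these compounds.

In an ADME assay on microsomes from liver (Rattus norvegicus, strain Sprague-Dawley) for pharmacokinetics, read by LC-MS, using NADPH, with a stated time of 45 min, tested at 1 uM (on this read-out lower numbers stand for slow clearance and higher numbers for fast clearance), compound 1 (`COc1cc(OCc2ccnc(N)n2)cc2sc(N[C@@H]3CCCC[C@H]3O)nc12`) gives 24 mL/min/kg and compound 2 (`COc1cc(OCc2ccnc(Nc3ccn(C)n3)n2)cc2sc(N[C@H]3CCCC[C@@H]3O)nc12`) gives 46.2 mL/min/kg, and these two values lie within the usual scatter of each other. Compound 3 (`COc1cc(OCc2ccnc(Nc3cn(C)nn3)n2)cc2sc(N[C@H]3CCCC[C@@H]3O)nc12`) differs from compound 2 in one place, on a nitrogen on an aromatic ring, where 1-methyl-1H-1,2,3-triazol-4-yl stands in place of 1-methyl-1H-pyrazol-3-yl: 1-methyl-1H-1,2,3-triazol-4-yl in place of 1-methyl-1H-pyrazol-3-yl on a nitrogen on an aromatic ring. For the measured compounds named here, no measured pair shows the effect of such a swap, so only a small change is expected. The expected step is a 1.2-fold lower number from compound 2 to compound 3 (0.08 log units; within the scatter), slightly toward slower clearance and within the scatter. For compound 3 the estimate is 38 mL/min/kg, with an expected range from 20 mL/min/kg to 65 mL/min/kg.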

Compound 3, clearance: 25 mL/min/kg
Compound 3: the middle estimate sits 1.5-fold (0.18 log units) above what was measured; the range from low to high includes it.
By their numbers in this assay, from the lowest: compounds 1, 3 and 2 (each within the scatter of the next).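

In this assay, for the compounds shown here, this is the first pair that differs in one place, and 1-methyl-1H-1,2,3-triazol-4-yl in place of 1-methyl-1H-pyrazol-3-yl gives a 1.8-fold lower number from compound 2 to compound 3 (0.27 log units; within the scatter). On this nitrogen on an aromatic ring, the two groups therefore cannot be told apart by clearance, even though one more ring carbon is exchanged for nitrogen. No measurement shown here bears on this result. On these data alone, whether a phenyl ring or a pyridine ring on the same nitrogen would also stay within the scatter remains open. So does whether this swap would read the same on a different core.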